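The source may hold more compounds than are shown below. What is called first, only, known or untested is meant among the compounds shown, and "the series" means these compounds.

Three compounds have been measured in an assay on isolated protein for inhibition of phosphatidylinositol 4,5-bisphosphate 3-kinase catalytic subunit beta isoform (Homo sapiens), read by 33P incorporation, with a stated time of 60 min; on this read-out higher numbers stand for weaker inhibition and lower numbers for stronger inhibition:
compound 1 `CCC/C(=N\NS(=O)(=O)c1cc([N+](=O)[O-])ccc1C)c1cnn2ccc(C#N)cc12` gives > 1000 nM, which is a limit of the assay.
compound 2 `C/C(=N\N(C)S(=O)(=O)c1cc([N+](=O)[O-])ccc1C)c1cnn2ccc(C#N)cc12` gives 600 nM.
compound 3 `CC/C(=N\N(C)S(=O)(=O)c1cc([N+](=O)[O-])ccc1C)c1cnn2ccc(C#N)cc12` gives > 1000 nM, again a limit of the assay.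

Compound 3 therefore stands at the limit: only a limit and no number is known for it, and compound 1 sits at that same limit (the limit of > 1000 nM in this assay, at which 2 of the 3 values shown sit). For the measured compounds named here, the one measured step that reaches compound 3 is an at least 1.6-fold higher number from compound 2 to compound 3 (0.22 log units; that floor lies within the scatter), a change of methyl in place of hydrogen on a saturated chain carbon bound to a carbon with a double bond to nitrogen; its floor lies within the scatter, so it shows at most that lengthening the chain brought no gain. Compound 4 `CCC/C(=N\N(C)S(=O)(=O)c1cc([N+](=O)[O-])ccc1C)c1cnn2ccc(C#N)cc12` carries the same kind of change cut one bond further out: methyl in place of hydrogen on a saturated chain carbon, two bonds along the chain from a carbon with a double bond to nitrogen, that is, methyl to ethyl, ethyl to propyl. Compound 1 also sits at the limit. No step beyond the scatter is available, so no gain is expected. Compound 4 is expected to show the step that the limit leaves unreadable from compound 3 to compound 4 and to remain at or past the limit. Compound 4 is estimated at 3000 nM, within 1000 nM to 10000 nM.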

Compound 4, half-maximal inhibitory concentration: > 1000 nM
Compound 4: a limit, no number; the forecaster's own chance of this, stated with the estimate: 85%; the middle value is on the limit's open side.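

In this assay compound 4 gives > 1000 nM, which is a limit of the assay and not a number. For the compounds shown here, the one readable step is an at least 1.6-fold higher number from compound 2 to compound 4 (0.22 log units; that floor lies within the scatter), a lengthening of the chain, so the propyl chain shows no gain over the methyl of compound 2, and no loss is established either. The steps to compound 4 from compound 3 and from compound 1 cannot be read, since both ends of each are limits: the limit of > 1000 nM in this assay, at which 3 of the 4 values shown sit.

The compounds shown leave open how far past the limit the ethyl and propyl compounds lie, and what the methyl on the sulfonamide nitrogen contributes. They also leave open what an isopropyl, a cyclopropyl or a chain ending in an amine would give at this place.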